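Chloro to Methyl on the Aryl Azide Core

The source may report more compounds than this note shows. Statements on the series, on what has been measured and on what is new or still open speak of the compounds shown alone.

Measured compounds:
Compound 1: `COc1cc2nc(Cc3cccc4ccccc34)[nH]c(=O)c2cc1OC` — 700 nM
Compound 2: `COc1cc2nc(-c3cccc(Cl)c3)nc(N=[N+]=[N-])c2cc1OC` — 10000 nM

In a functional assay on HCT-116 cells (Homo sapiens) for cytotoxicity, read by MTT assay, with a stated time of 72 h (a lower number here means a stronger inhibitor, a higher number a weaker inhibitor), compound 1 gives 700 nM, while compound 2 gives 10000 nM. Compound 2 thus stands at the higher of the two numbers, and its gap to compound 1 lies beyond the usual scatter. The two compounds differ in several places at once, so the measured pair does not isolate any single change.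

The next compound, compound 3, is `COc1cc2nc(-c3cccc(C)c3)nc(N=[N+]=[N-])c2cc1OC`. Relative to compound 2 the change is methyl in place of chloro on an aromatic carbon. Among the compounds with values here, no measured pair in this set carries this exchange, and one heavy atom is swapped for another of the same count, so a step of no more than the scatter, in either direction, is expected from compound 2 to compound 3.

Compound 3 is therefore expected to give 10000 nM, with a range from 4000 nM to 25000 nM. The step of no change at the digits printed from compound 2 to compound 3 (within the scatter) implied by this estimate is expected to remain within the scatter.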

Compound 3, half-maximal inhibitory concentration: > 10000 nM
Compound 3 gave a limit, no number (the forecaster's own chance of this, stated with the estimate: 30%); the middle value sits exactly at the limit.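

Within the data shown here, this exchange gives the first comparison in the set between compounds that differ in one place: in this assay, methyl in place of chloro gives a number no lower from compound 2 to compound 3 (the limit leaves the size open). Compound 3 gives > 10000 nM, which is a limit of the assay and not a number. The 3-methylphenyl group therefore brings no readable gain over the 3-chlorophenyl group at this carbon, and the size of the step cannot be read, so it cannot be placed within or beyond the scatter: the limit of > 10000 nM in this assay, at which 1 of the 3 values shown sits.

The compounds shown leave open whether an amine or a carboxylic acid on this aromatic carbon would give a lower number. They also leave open whether methyl and chloro would separate on the same carbon if the azide were replaced by an amine.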